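The compounds below may be only part of what the source reports. "The series", "measured", "known", "first", "only" and "open" are said of these compounds alone.

Measured compounds:
compound 1, `COc1ccccc1NC(=O)Nc1cccc(CNc2ncnc3cc(OC)c(OC)cc23)c1` — 7710 nM
compound 2, `COc1cc2ncnc(NCc3cccc(NC(=O)Nc4ccccc4Cl)c3)c2cc1OC` — 30200 nM

In a functional assay on MGC-803 cells (Homo sapiens) for antiproliferative activity, read by MTT assay (a higher number here means a weaker inhibitor, a lower number a stronger inhibitor), compound 2 stands at the highest of the two numbers; its nearest neighbour is compound 1, and the step of a 3.9-fold higher number from compound 1 to compound 2 (0.59 log units; beyond the scatter) lies beyond the scatter. Compound 3, `COc1cc2ncnc(NCc3cccc(NC(=O)Nc4ccc([N+](=O)[O-])cc4)c3)c2cc1OC`, is not yet measured. The change is 4-nitrophenyl in place of 2-chlorophenyl on an amide-type nitrogen. Among the compounds with values here, no measured step covers this exchange; the only known step on that aryl ring, a 3.9-fold higher number from compound 1 to compound 2 (0.59 log units; beyond the scatter), is modest and concerns a different pair of groups, so it gives no direction here. Compound 3 is therefore expected to stay near compound 2, with a wide range: 22000 nM, between 6000 nM and 70000 nM, a step of a 1.4-fold lower number from compound 2 to compound 3 (0.14 log units; within the scatter).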

Compound 3, half-maximal inhibitory concentration: 8120 nM
Beside the measured number, compound 3's estimate is 2.7-fold (0.43 log units) above it; low and high end bracket the measured number.
By their numbers in this assay, from the lowest: compounds 1 and 3 (each within the scatter of the next); then compound 2.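

In this assay, a 3.7-fold lower number from compound 2 to compound 3 (0.57 log units; beyond the scatter) comes with 4-nitrophenyl in place of 2-chlorophenyl on the amide-type nitrogen, so this position responds to more than the earlier chloro-for-methoxy exchange showed. With a 1.1-fold higher number from compound 1 to compound 3 (0.02 log units; within the scatter) for 4-nitrophenyl in place of 2-methoxyphenyl, compound 2 alone stands apart among the three. No evidence on the cause of these steps is available.

The compounds shown leave open how 4-chlorophenyl or 4-aminophenyl would compare on this nitrogen, so the effect of the substituent stays unseparated from that of its place on the ring.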